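A Sulfur-Bearing Side Chain on a Weakly Active Core

A few compounds are considered here, and "the series" means these few. Any claim that something is new, unique, unknown or untested is made for them only; others in the source may bear on it.

Compound 2 `CC(C)C[C@@H]1NC(=O)[C@H](CC(N)=O)NC1=O` gives 170000 nM in a functional assay; a lower number here means a stronger inhibitor, a higher number a weaker inhibitor. Among the two compounds measured so far, compound 2 has the highest number; its nearest neighbour is compound 1 `CC(C)C[C@@H]1NC(=O)[C@H](CCCCN)NC1=O`, which in this assay gives 160000 nM, and the step of a 1.1-fold higher number from compound 1 to compound 2 (0.03 log units; within the scatter) lies within the scatter. Compound 3 `CSCC[C@@H]1NC(=O)[C@H](CC(C)C)NC1=O` has not yet been measured in this assay. It differs from compound 2 as follows: (methylsulfanyl)methyl in place of carbamoyl on a saturated chain carbon bound to a saturated ring carbon. Among the compounds with values here, the only measured step that bears on this change is the one already described from compound 1 to compound 2, made at the same place on the shared core, and it stayed within the scatter. With no other guidance available, the step of no change at the digits printed from compound 2 to compound 3 (within the scatter) is expected to remain within the scatter as well. Compound 3 is therefore estimated at 170000 nM in this assay, with a range from 60000 nM to 450000 nM.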

Compound 3, half-maximal inhibitory concentration: 800000 nM
Estimate against measurement, compound 3: 4.7-fold (0.67 log units) below; measured number outside the range, above it.
By their numbers in this assay, from the lowest: compounds 1 and 2 (each within the scatter of the next); then compound 3.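

In this assay this position turns out not to be indifferent to its side chain: the earlier pair stayed within the scatter, but (methylsulfanyl)methyl in place of carbamoyl gives a 4.7-fold higher number from compound 2 to compound 3 (0.67 log units; beyond the scatter) and counts as a real loss. Methylsulfanyl in place of 2-aminoethyl points the same way, with a 5.0-fold higher number from compound 1 to compound 3 (0.70 log units; beyond the scatter) on the same core, so compound 3 is the weakest inhibitor of the three, and the two polar-ended chains of compound 1 and compound 2 are not interchangeable with this sulfur-bearing one. Nothing at hand accounts for this loss.

The compounds shown leave open whether the sulfur itself or the absence of the carbamoyl or amine end drives the step. A plain butyl chain, a carboxylic acid or a longer amine at this place could help separate these readings.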